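The source may report more compounds than this note shows. Statements on the series, on what has been measured and on what is new or still open speak of the compounds shown alone.

Of the compounds shown here, three have been tested in a functional assay on the whole organism for antagonist activity, with Mus musculus as the target (on this read-out higher numbers stand for an effect only at larger amounts of compound and lower numbers for an effect already at smaller amounts), and a fourth remains to be measured. Compound 1 `CCOC(=O)N(C)CC#CCN1CCCC1` carries an ethoxycarbonyl group and a pyrrolidin-1-yl group. In this assay compound 1 gives > 100 mg/kg, which is a limit of the assay and not a number. Compound 2 `CCOC(=O)N(C)CC#CCn1ccnc1` differs from compound 1 in one place: 1H-imidazol-1-yl in place of pyrrolidin-1-yl on a saturated chain carbon bound to a triple-bonded carbon. In this assay compound 2 gives > 100 mg/kg, again a limit rather than a number. Between them stands a step that the two limits leave unreadable from compound 1 to compound 2. Compound 3 `CN(C)C(=O)N(C)CC#CCN1CCCC1` has a different core from compound 1, the two cores differing as follows: dimethylamino in place of ethoxy on a carbonyl carbon. In this assay compound 3 gives > 10 mg/kg, which is likewise a limit. Between them stands a step that the two limits leave unreadable from compound 1 to compound 3. Compound 4 `CN(C)C(=O)N(C)CC#CCn1ccnc1` has not yet been measured; it differs from compound 3 in one place: 1H-imidazol-1-yl in place of pyrrolidin-1-yl on a saturated chain carbon bound to a triple-bonded carbon. This is the same change as from compound 1 to compound 2, made at the same place. What the measured compounds offer is only limits, namely the limit of > 10 mg/kg in this assay, at which 1 of the 3 values shown sits, and (the limit of > 100 mg/kg in this assay, at which 2 of the 3 values shown sit), so no readable step is available for this change. The step that the limit leaves unreadable from compound 3 to compound 4 is therefore expected to be small, because a step that the two limits leave unreadable from compound 1 to compound 2 gave no sign of a readable change. Compound 4 is expected to give about 50 mg/kg in this assay. The estimate for compound 4 spans from 10 mg/kg to 300 mg/kg, and a limit rather than a number is the likely outcome.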

Compound 4, dose for half-maximal effect: > 100 mg/kg
Compound 4: only a limit was reported (the forecaster's own chance of this, stated with the estimate: 85%); middle value at least 2.0-fold (0.30 log units) away from the limit.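

In this assay compound 4 gives > 100 mg/kg, which is a limit and not a number. Neither the step from compound 3 to compound 4 nor the step from compound 2 to compound 4 can be read, as only limits stand at their ends. The compounds shown leave open whether either exchange, of pyrrolidin-1-yl for 1H-imidazol-1-yl or of ethoxy for dimethylamino, changes the dose needed at all.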